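Swapping the Aryl on the Sulfonyl Before Compound 3

The source may hold more compounds than are shown below. What is called first, only, known or untested is meant among the compounds shown, and "the series" means these compounds.

Measured so far in a functional assay on A549 cells (Homo sapiens) for cytotoxicity, read by MTT assay, with a stated time of 72 h; a lower number here means a stronger inhibitor, a higher number a weaker inhibitor:
Compound 1 `COc1cc2c(Oc3ccc(NC(=O)c4cn(-c5ccc(Cl)cc5)cn4)cc3F)ccnc2cc1OCCCN1CCCCC1` gives 6560 nM.
Compound 2 `COc1cc2c(Oc3ccc(NC(=O)/C=C/S(=O)(=O)c4ccccc4OC)cc3F)ccnc2cc1OCCCN1CCCCC1` gives 470 nM.

Compound 2 holds the lowest of the two numbers in this assay. Among the measured compounds shown here, the only comparison available is with compound 1, whose value is markedly higher, a gap well beyond the scatter of repeated measurements; no single-point step connects the two, so the comparison says only what the two values show.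

Compound 3 `COc1cc2c(Oc3ccc(NC(=O)/C=C/S(=O)(=O)c4ccc(C)cc4)cc3F)ccnc2cc1OCCCN1CCCCC1` is the next compound to be measured. It differs from compound 2 in one place: 4-methylphenyl in place of 2-methoxyphenyl on a sulfonyl sulfur. The shared core and the unsaturated amide linkage are kept. For the measured compounds named here, no measured pair in this set isolates a change on the sulfonyl aryl group, so there is no step to lean on.

With nothing shown to move the number strongly, compound 3 is expected to land close to compound 2, with the estimated step of a 1.4-fold higher number from compound 2 to compound 3 (0.14 log units; within the scatter) falling within or near the scatter. Compound 3 is therefore estimated at 650 nM, in the range 160 nM to 2600 nM.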

Compound 3, half-maximal inhibitory concentration: 2310 nM
The estimate for compound 3 lay 3.6-fold (0.55 log units) below the measured number, within the range that was stated.
By their numbers in this assay, from the lowest: compound 2; then compound 3; then compound 1.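

In this assay, the aryl group on the sulfonyl sulfur proves to be a place where the number responds: 4-methylphenyl in place of 2-methoxyphenyl gives a 4.9-fold higher number from compound 2 to compound 3 (0.69 log units; beyond the scatter), a modest change but beyond the scatter. Compound 3 still stands apart from compound 1, with a 2.8-fold lower number from compound 1 to compound 3 (0.45 log units; beyond the scatter), so 2-((4-methylphenyl)sulfonyl)ethenyl in place of 1-(4-chlorophenyl)-1H-imidazol-4-yl on a carbonyl carbon also gives a modest change beyond the scatter, even with the less favourable of the two sulfonyl aryl groups. The swap from compound 2 to compound 3 removes a hydrogen-bond acceptor and changes both the substituent and its printed position in a single step, and no measurement here explains the resulting shift. On these data alone, it therefore remains open whether the methoxy group, the methyl group or the substituent position governs the number. An unsubstituted phenyl or a pyridyl group on the sulfonyl sulfur would help to show which of these readings holds, and whether the number can fall below that of compound 2 at 470 nM.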